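Swapping a hydroxyphenyl arm on the shared core

The compounds below may be only part of what the source reports. "The series", "measured", "known", "first", "only" and "open" are said of these compounds alone.

Of the compounds shown here, three built on a shared core have been measured in a functional assay on T47D cells (Homo sapiens) for cytotoxicity, read by CCK-8 assay, with a stated time of 4 days; a lower number here means a stronger inhibitor, a higher number a weaker inhibitor. Compound 1 `Oc1ccc(-c2cc(-c3cccc(O)c3)nc(-c3ccccc3O)c2)cc1` gives 4810 nM, compound 2 `Oc1ccc(-c2cc(-c3cccc(O)c3)nc(-c3cccc(O)c3)c2)cc1` gives 2230 nM, and compound 3 `Oc1cccc(-c2cc(-c3ccccc3O)cc(-c3ccccc3O)n2)c1` gives 5760 nM. Compound 3 stands with the highest number of the three; its gap to compound 1 is within the scatter, while its gap to compound 2 is beyond it.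

Compound 4 `Oc1cccc(-c2cc(-c3ccccc3O)cc(-c3cccc(O)c3)n2)c1` is the next step from compound 3. The change is 3-hydroxyphenyl in place of 2-hydroxyphenyl on an aromatic carbon, made on an aromatic carbon of the core, next to the ring nitrogen, meta to a 2-hydroxyphenyl group and meta to a 3-hydroxyphenyl group.

Among the compounds with values here, one measured step bears on this change: a 2.2-fold lower number from compound 1 to compound 2 (0.33 log units; beyond the scatter), the same swap of groups. Against that, a 1.2-fold higher number from compound 1 to compound 3 (0.08 log units; within the scatter) shows that shifting a hydroxyl between ring positions can also leave the number unchanged. A modest lowering is therefore expected for compound 4 in this assay, a 2.1-fold lower number from compound 3 to compound 4 (0.33 log units; beyond the scatter). Compound 4 is estimated at 2700 nM, with a range from 1300 nM to 5500 nM.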

Compound 4, half-maximal inhibitory concentration: 4570 nM
Estimate against measurement, compound 4: 1.7-fold (0.23 log units) below; the range from low to high includes it.
By their numbers in this assay, from the lowest: compound 2; then compounds 4, 1 and 3 (each within the scatter of the next).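

At this position, next to the ring nitrogen, 3-hydroxyphenyl in place of 2-hydroxyphenyl gives a 1.3-fold lower number from compound 3 to compound 4 (0.10 log units; within the scatter), so the swap that went beyond the scatter on the earlier pair does not do so here, although the two steps cannot be told apart: the same change on two cores in this assay, a 2.2-fold lower number (0.33 log units; beyond the scatter) from compound 1 to compound 2 and a 1.3-fold lower number (0.10 log units; within the scatter) from compound 3 to compound 4, 1.7-fold (0.23 log units) apart, within the scatter of two such steps The other swap, 2-hydroxyphenyl in place of 4-hydroxyphenyl, gives a 2.0-fold higher number from compound 2 to compound 4 (0.31 log units; beyond the scatter), while its earlier counterpart stayed within the scatter, and again the two steps cannot be told apart: the same change on two cores in this assay, a 1.2-fold higher number (0.08 log units; within the scatter) from compound 1 to compound 3 and a 2.0-fold higher number (0.31 log units; beyond the scatter) from compound 2 to compound 4, 1.7-fold (0.23 log units) apart, within the scatter of two such steps Each swap thus runs in one direction on both cores, but its size on one core cannot be separated from its size on the other.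

The compounds shown leave open how a methoxy group or an amine in place of the hydroxyl would read in this assay. As far as these compounds go, an unsubstituted phenyl at this position also remains open.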